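This account rests on a few compounds, and the source may have more. Where it says the series, first, only, none or still open, it means among the compounds named here.

Compound 3 `CN1C[C@H](C(=O)Nc2ccc(Cl)c(Cl)c2)[C@@H](c2ccc(/C=C/C(=O)Nc3ccccc3N)cc2)C1` gives 36 mL/min/kg in an in vitro ADME assay on microsomes from liver (Mus musculus) for pharmacokinetics, read by LC-MS, with a stated time of 10 min, tested at 1 uM (a lower number here means slower removal, a higher number faster removal of the compound), the second highest of the three numbers. Compound 2 `CN1C[C@H](C(=O)Nc2ccc(F)c(Cl)c2)[C@@H](c2ccc(/C=C/C(=O)Nc3ccccc3N)cc2)C1` gives 34 mL/min/kg, and the step of a 1.1-fold higher number from compound 2 to compound 3 (0.02 log units; within the scatter) lies within the scatter. Compound 1 `Cc1cccc(NC(=O)[C@H]2CN(C)C[C@@H]2c2ccc(/C=C/C(=O)Nc3ccccc3N)cc2)c1` gives 74 mL/min/kg, so the step of a 2.1-fold lower number from compound 1 to compound 3 (0.31 log units; beyond the scatter) is modest, as is a 2.2-fold lower number from compound 1 to compound 2 (0.34 log units; beyond the scatter). Compound 4 `CN1C[C@H](C(=O)NC2CC2)[C@@H](c2ccc(/C=C/C(=O)Nc3ccccc3N)cc2)C1` differs from compound 3 by the change (cyclopropyl in place of 3,4-dichlorophenyl on an amide-type nitrogen). Going by the values given here, none of the measured steps swaps the aryl group for a ring of that kind; the two modest steps only exchanged one aryl for another. The step of a 1.2-fold lower number from compound 3 to compound 4 (0.08 log units; within the scatter) is therefore expected to be small, with no firm direction. Compound 4 is estimated at 30 mL/min/kg in this assay, within a range from 14 mL/min/kg to 65 mL/min/kg.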

Compound 4, clearance: 7 mL/min/kg
Compound 4: the middle estimate sits 4.3-fold (0.63 log units) above what was measured, outside the stated range (below it).
By their numbers in this assay, from the lowest: compound 4; then compounds 2 and 3 (each within the scatter of the next); then compound 1.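

In this assay the number falls whichever aryl group leaves the amide-type nitrogen for cyclopropyl, with a 5.1-fold lower number from compound 3 to compound 4 (0.71 log units; beyond the scatter) and a 4.9-fold lower number from compound 2 to compound 4 (0.69 log units; beyond the scatter) and also an 11-fold lower number from compound 1 to compound 4 (1.02 log units; beyond the scatter) as the three steps. The earlier compounds shown here carried only aryl groups at this place, so they could not show that a non-aromatic ring here gives the lowest number of the four compounds.

As far as these compounds go, it remains open whether this holds only for cyclopropyl or also for cyclobutyl, an isopropyl group or a longer chain ending in an amine. No measurement at hand accounts for the fall.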